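Amide side-chain aryl change: compound 2 to compound 3

The source may hold more compounds than are shown below. What is called first, only, known or untested is meant among the compounds shown, and "the series" means these compounds.

Measured so far in a functional assay on SW480 cells (Homo sapiens) for cytotoxicity, read by MTT assay, with a stated time of 24 h; a higher number here means a weaker inhibitor, a lower number a stronger inhibitor:
compound 1, `C=CC1=C(C(=O)NCc2ccc(C)cc2)C(c2ccc(F)cc2)OC1`, gives a limit only, > 100000 nM
compound 2, `C=CC1=C(C(=O)NCc2ccc(Cl)cc2)C(c2ccc(F)cc2)OC1`, gives a limit only, > 100000 nM

Compound 2 stands at a limit in this assay, not at a number. The step that the two limits leave unreadable from compound 1 to compound 2 cannot be sized because of the limit of > 100000 nM in this assay, at which 2 of the 2 values shown sit. Compound 3, `C=CC1=C(C(=O)NCc2ccccc2F)C(c2ccc(F)cc2)OC1`, carries 2-fluorophenyl in place of 4-chlorophenyl on a saturated chain carbon bound to an amide-type nitrogen. No readable measured step bears on this change. Compound 3 is therefore expected to stay at the limit, the estimated value being 100000 nM, within 30000 nM to 300000 nM. The expected step is a number no higher from compound 2 to compound 3 (the limit leaves the size open), none beyond the scatter.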

Compound 3, half-maximal inhibitory concentration: > 100000 nM
Compound 3 was reported as a limit; the forecaster's own chance of this, stated with the estimate: 85%; the middle value lies on the limit itself.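

Going by these compounds alone, no step among compound 1, compound 2 and compound 3 can be read in this assay, as all three stand at a limit: the limit of > 100000 nM in this assay, at which 3 of the 3 values shown sit. The compounds shown leave open whether any benzyl group on the amide would give a readable value.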